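Series notes: from compound 3 to compound 4

This account rests on a few compounds, and the source may have more. Where it says the series, first, only, none or still open, it means among the compounds named here.

Three compounds have numbers in a functional assay on the whole organism (Abdomen, strain Swiss) for inhibition, with Mus musculus as the target, with stated times of 30 min, 10 min and 5 min, at a dose of 20 mg/kg by the oral route; on this read-out higher numbers stand for a stronger effect at the one dose given and lower numbers for a weaker effect. Compound 3 `CC(=O)c1cccn1CCCN1CCN(c2cccc(Cl)c2)CC1` stands highest: in this assay compound 3 gives 41%. Compound 2 `Cc1c(C#N)c(-c2ccccc2)nn1CCCN1CCN(c2ccc(F)cc2)CC1` comes nearest, and in this assay compound 2 gives 28%, a gap beyond the scatter. Compound 1 `CCCCC(=O)c1c(C)nn(CCCN2CCN(c3ccc(C)cc3)CC2)c(=O)c1N` lies furthest off; in this assay compound 1 gives 23%, also beyond the scatter. Compound 4 `CC(=O)c1cccn1CCCN1CCN(c2ccc(C)cc2)CC1` is not yet measured. It differs from compound 3 in one place: 4-methylphenyl in place of 3-chlorophenyl on an amine nitrogen in a ring. Among the measured compounds shown here, no measured pair shows this change on a shared core, so no step can be read off. Compound 1 carries the same 4-methylphenyl on an amine nitrogen in a ring and sits lowest, but its core differs. A modest downward step is expected, a number 9 percentage points lower from compound 3 to compound 4 (within the scatter). Compound 4 is estimated at 32%, with a range from 15% to 50%.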

Compound 4, a percentage reported as inhibition, in the whole organism at one dose (the size of the read-out at that dose, not a potency): 7%
Compound 4: middle estimate off by 25 percentage points, on the high side, outside the stated range (below it).
By their numbers in this assay, from the lowest: compound 4; then compounds 1 and 2 (each within the scatter of the next); then compound 3.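

On the shared core, 4-methylphenyl in place of 3-chlorophenyl on an amine nitrogen in a ring brings a large fall in this assay (a number 34 percentage points lower from compound 3 to compound 4 (beyond the scatter)). Among the compounds shown here, this is the first step that can be read at this position, and it shows that the read-out depends strongly on the group here, even though both groups are carbon-only aromatic rings with no hydrogen-bond donors or acceptors. Nothing at hand gives a cause for the step.

From the compounds shown here alone, whether the fall follows the change from chlorine to methyl or the different placement on the phenyl ring stays open. A 4-chlorophenyl or a 3-methylphenyl on the same core would separate the two.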